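Aryl changes on an anilino-pyrimidine urea: compound 4 expected

This account rests on a few compounds, and the source may have more. Where it says the series, first, only, none or still open, it means among the compounds named here.

Measured compounds:
compound 1 `COc1cc(NC(=O)Nc2cc(Nc3ccc(OC)c(C)c3)ncn2)cc(OC)c1` — 39.7%
compound 2 `CCc1cccc(Nc2cc(NC(=O)Nc3cc(OC)cc(OC)c3)ncn2)c1` — 36.7%
compound 3 `COc1cc(NC(=O)Nc2cc(Nc3cccc(C(C)(C)C)c3)ncn2)cc(OC)c1` — 40%

In a functional assay on NCI-H226 cells (Homo sapiens) for inhibition, read by MTT assay, with a stated time of 48 h, tested at 10 uM (a higher number here means more inhibition at the concentration tested (going by the name of the read-out), a lower number less inhibition), the three compounds sit close together. Compound 3 holds the highest of the three numbers, but a number 0.3 percentage points higher from compound 1 to compound 3 (within the scatter) and a number 3.3 percentage points higher from compound 2 to compound 3 (within the scatter) show that neither gap separates it from the others, as does a number 3 percentage points lower from compound 1 to compound 2 (within the scatter) between the other two.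

Compound 4 `COc1cc(NC(=O)Nc2cc(Nc3ccc(OC)c(I)c3)ncn2)cc(OC)c1` is not yet measured. It differs from compound 3 by 3-iodo-4-methoxyphenyl in place of 3-(tert-butyl)phenyl on a nitrogen on an aromatic ring. The nearest measured comparison is compound 1, whose 4-methoxy-3-methylphenyl shares the methoxy with the entering group, and the step of a number 0.3 percentage points higher from compound 1 to compound 3 (within the scatter) was small. All three aryl swaps so far left this assay essentially unchanged, so compound 4 is expected to give 39% (range 27% to 52%), a step of a number 1 percentage points lower from compound 3 to compound 4 (within the scatter) that stays within the scatter.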

Compound 4, a percentage reported as inhibition, at one concentration (the size of the read-out at that concentration, not a potency): 40.1%
For compound 4 the middle estimate is 1.1 percentage points below the measured one; measured number inside the range.
By their numbers in this assay, from the lowest: compounds 2, 1, 3 and 4 (each within the scatter of the next).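

In this assay, iodo in place of methyl on the aromatic carbon gives a number 0.4 percentage points higher from compound 1 to compound 4 (within the scatter), so this first halogen in the series leaves the number where the methyl compound had it. The larger swaps on the nitrogen read the same way, with a number 0.1 percentage points higher from compound 3 to compound 4 (within the scatter) and a number 3.4 percentage points higher from compound 2 to compound 4 (within the scatter), so the 3-iodo-4-methoxyphenyl group cannot be told apart from the alkyl-bearing aryl groups. Nothing available explains why these changes leave the number flat. As far as these compounds go, whether an amine or a carboxylic acid on this aryl ring would move the number remains open, as does the effect of changing the other aryl group on the shared core.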